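Para-substituent swap on the aryl ring of the core

A few compounds are considered here, and "the series" means these few. Any claim that something is new, unique, unknown or untested is made for them only; others in the source may bear on it.

Measured compounds in the series:
- compound 1 `Cc1ccc(-c2cc(N3CCC(CNS(N)(=O)=O)CC3)ncn2)cc1`: 30600 nM
- compound 2 `CCCCc1ccc(-c2cc(N3CCC(CNS(N)(=O)=O)CC3)ncn2)cc1`: 21800 nM
- compound 3 `CC(C)(C)c1ccc(-c2cc(N3CCC(CNS(N)(=O)=O)CC3)ncn2)cc1`: 19700 nM

All three were read in a functional assay on MCF7 cells (Homo sapiens) for antiproliferative activity, read by sulforhodamine B assay, with a stated time of 48 h; on this read-out higher numbers stand for weaker inhibition of growth and lower numbers for stronger inhibition of growth. Compound 1 gives the highest number of the three, but its neighbours sit close: a 1.4-fold lower number from compound 1 to compound 2 (0.15 log units; within the scatter) and a 1.6-fold lower number from compound 1 to compound 3 (0.19 log units; within the scatter) are both within the scatter, as is a 1.1-fold lower number from compound 2 to compound 3 (0.04 log units; within the scatter). On these numbers the three compounds cannot be told apart.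

The next compound, compound 4 `COc1ccc(-c2cc(N3CCC(CNS(N)(=O)=O)CC3)ncn2)cc1`, keeps the shared core of compound 1 and changes only the aryl substituent: methoxy in place of methyl on an aromatic carbon. Going by the values given here, the steps that bear on this change are those that alter the same aromatic substituent, compound 1 to compound 3 and compound 2 to compound 3, and neither moved the number beyond the scatter. Among the compounds with values here, nothing measured so far suggests that a change at this position shifts growth inhibition in either direction. The expectation for compound 4 in this assay is therefore no step beyond the scatter, a 1.1-fold lower number from compound 1 to compound 4 (0.05 log units; within the scatter), and compound 4 is estimated at 27000 nM, with a range from 12000 nM to 60000 nM.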

Compound 4, concentration for 50% growth inhibition: 35300 nM
The estimate for compound 4 lay 1.3-fold (0.12 log units) below the measured number, and the stated range covers the measured number.
By their numbers in this assay, from the lowest: compounds 3, 2, 1 and 4 (each within the scatter of the next).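

In this assay, going by these compounds alone, the change from 4-methylphenyl to 4-methoxyphenyl is the first at this position to bring in an oxygen and a hydrogen-bond acceptor, and a 1.2-fold higher number from compound 1 to compound 4 (0.06 log units; within the scatter) shows that this swap does not move the number beyond the scatter. Set against the other carbon-only groups the result is the same, with a 1.8-fold higher number from compound 3 to compound 4 (0.25 log units; within the scatter) and a 1.6-fold higher number from compound 2 to compound 4 (0.21 log units; within the scatter) as the widest steps at this position, so methyl, butyl, tert-butyl and methoxy on this aromatic carbon, para to a large group, cannot be told apart on growth inhibition. No supporting data accompany these compounds that could say anything about why the four read alike.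

Still open, going by these compounds, is whether a group of another kind at this position, such as an amine or a carboxylic acid, would give a step beyond the scatter. The compounds shown also leave open whether the number responds to any change outside this aryl substituent, since all four keep the shared core unchanged.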